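The source may hold more compounds than are shown below. What is called first, only, known or untested is meant among the compounds shown, and "the series" means these compounds.

Compound 3 `O=C(/C=C/c1ccc2c(c1)B(O)OC2)c1cccc(F)c1` is the strongest of the three compounds measured in a functional assay on MDA-MB-231 cells (Homo sapiens) for cytotoxicity, read by MTT assay, with a stated time of 48 h (a lower number here means a stronger inhibitor, a higher number a weaker inhibitor), where compound 3 gives 3000 nM. Compound 1 `O=C(/C=C/c1ccc2c(c1)B(O)OC2)c1ccc(Cl)cc1` gives 7900 nM in this assay, and compound 2 `Nc1ccc(C(=O)/C=C/c2ccc3c(c2)B(O)OC3)cc1` gives 25800 nM. The steps between them are all modest: a 2.6-fold lower number from compound 1 to compound 3 (0.42 log units; beyond the scatter), an 8.6-fold lower number from compound 2 to compound 3 (0.93 log units; beyond the scatter), and a 3.3-fold higher number from compound 1 to compound 2 (0.51 log units; beyond the scatter).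

Compound 4 `Cc1cccc(C(=O)/C=C/c2ccc3c(c2)B(O)OC3)c1` differs from compound 3 by methyl in place of fluoro on an aromatic carbon. Within the data shown here, none of the measured steps swaps one substituent for another at this ring carbon; the nearest comparison is the step of a 3.3-fold higher number from compound 1 to compound 2 (0.51 log units; beyond the scatter), which exchanged one substituent for another on the aromatic ring of the carbonyl-bound phenyl and moved the number by a modest amount. The step of a 2.6-fold lower number from compound 1 to compound 3 (0.42 log units; beyond the scatter) changed both the substituent and its position at once, so it offers no clean guide for this single exchange. On that basis the change from compound 3 to compound 4 is expected to produce at most a modest step in this assay, with no firm indication of direction, leaning toward a somewhat higher number.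

Compound 4 is therefore estimated to give 4500 nM in this assay, within a range from 1800 nM to 12000 nM, which would mean an expected step of a 1.5-fold higher number from compound 3 to compound 4 (0.18 log units; within the scatter).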

Compound 4, half-maximal inhibitory concentration: 4500 nM
Compound 4: the middle estimate sits on the measured number at the digits printed; the measured number falls inside the stated range.
By their numbers in this assay, from the lowest: compounds 3, 4 and 1 (each within the scatter of the next, the first and the last beyond it); then compound 2.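

The exchange of fluoro for methyl on an aromatic carbon, meta to a large group, gives a 1.5-fold higher number from compound 3 to compound 4 (0.18 log units; within the scatter) in this assay, the first step shown that changes only the group at this ring carbon, and the assay does not separate the two compounds. With 3-methylphenyl on the carbonyl carbon, the compound keeps the distance from the 4-aminophenyl compound, at a 5.7-fold lower number from compound 2 to compound 4 (0.76 log units; beyond the scatter), while a 1.8-fold lower number from compound 1 to compound 4 (0.24 log units; within the scatter) leaves it unresolved from the 4-chlorophenyl compound, although the 3-fluorophenyl compound stands clear of that compound. Nothing measured here explains why these numbers fall as they do.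

The compounds shown leave open whether a different group at this carbon, such as a methoxy group, a trifluoromethyl group or an amine, would also stay this close to compound 3. Nor can the gap to compound 2 be assigned to the group or to its position alone, as 4-aminophenyl and 3-methylphenyl differ in both.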